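This account rests on a few compounds, and the source may have more. Where it says the series, first, only, none or still open, it means among the compounds named here.

Of the compounds shown here, two built on a shared core have been measured in a functional assay on OVCAR-8 cells (Homo sapiens) for antiproliferative activity; a lower number here means a stronger inhibitor, a higher number a weaker inhibitor. Compound 1 `Cn1ncc(Cl)c1-c1cc(C(=O)N[C@@H]2CN[C@H](CC(=O)NCC(O)CO)C[C@H]2c2ccc(Cl)c(Cl)c2)oc1Cl` gives 5900 nM in this assay, and compound 2 `Cn1ncc(Cl)c1-c1cc(C(=O)N[C@@H]2CN[C@H](CCN3CCCCC3)C[C@H]2c2ccc(Cl)c(Cl)c2)oc1Cl` gives 1660 nM. Within the data shown here, compound 2 therefore holds the lower of the two numbers, with a 3.6-fold lower number from compound 1 to compound 2 (0.55 log units; beyond the scatter) separating it from compound 1, the only step available so far. The next compound, compound 3 `Cn1ncc(Cl)c1-c1cc(C(=O)N[C@@H]2CN[C@H](CCCO)C[C@H]2c2ccc(Cl)c(Cl)c2)oc1Cl`, differs from compound 2 in one place: hydroxymethyl in place of piperidin-1-yl on a saturated chain carbon, two bonds along the chain from a saturated ring carbon. Among the measured compounds shown here, the single measured step that bears on this change is the one from compound 1 to compound 2, where (2,3-dihydroxypropyl)carbamoyl gave way to (piperidin-1-yl)methyl and the number fell modestly. Compound 3 returns to a chain ending in a hydroxyl group, though a shorter one without the carbamoyl, so the reverse direction is the natural guess, with the number rising but not all the way back. Compound 3 is therefore expected to show a step of a 2.3-fold higher number from compound 2 to compound 3 (0.36 log units; beyond the scatter) in this assay, toward a weaker inhibitor. For compound 3 the estimate in this assay is 3800 nM, with a range from 1400 nM to 10000 nM.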

Compound 3, half-maximal inhibitory concentration: 600 nM
Beside the measured number, compound 3's estimate is 6.3-fold (0.80 log units) above it; measured number below the stated range.
By their numbers in this assay, from the lowest: compound 3; then compound 2; then compound 1.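

In this assay, hydroxymethyl in place of piperidin-1-yl gives a 2.8-fold lower number from compound 2 to compound 3 (0.44 log units; beyond the scatter), so the piperidine ring is not needed here to reach the lowest number among the three compounds, and a chain ending in a hydroxyl group is not in itself a drawback at this position. This reverses the simple reading of the earlier pair, in which the hydroxyl-bearing chain had the higher number. The 2-hydroxyethyl group in place of (2,3-dihydroxypropyl)carbamoyl gives a 9.8-fold lower number from compound 1 to compound 3 (0.99 log units; beyond the scatter), the widest gap seen so far. Compound 1 and compound 3 both carry a hydroxyl group, yet they hold the highest and the lowest number of the three, and nothing available explains why the three chain ends rank as they do.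

Still open, on these data alone, is whether the hydroxyl group of compound 3 contributes at all or whether the chain alone is enough, a question that a plain propyl chain or a methyl ether at the same place would address. As far as these compounds go, how far the chain can change also remains unknown, for example with a longer 4-hydroxybutyl chain or a carboxylic acid at its end.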